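The source may hold more compounds than are shown below. What is called first, only, known or untested is meant among the compounds shown, and "the series" means these compounds.

Compound 1 `O=C(NCc1ccccc1)c1c([N+](=O)[O-])noc1-c1ccc(Cl)cc1`, compound 2 `O=C(NCc1ccc(F)cc1)c1c([N+](=O)[O-])noc1-c1ccc(Cl)cc1` and compound 3 `COc1ccc(CNC(=O)c2c([N+](=O)[O-])noc2-c2ccc(Cl)cc2)cc1` share one core. In an ADME assay on J774.A1 cells (Mus musculus) for cytotoxicity, read by MTT assay, with a stated time of 48 h (a lower number here means that less compound is tolerated, a higher number that more compound is tolerated), compound 1 gives "not determined" (no result reported), so it offers no number for comparison. Within the data shown here, compound 2 gives 91900 nM and compound 3 gives 89500 nM, which places compound 3 level with the only other measured number. Compound 4 `COc1ccc(CNC(=O)c2c([N+](=O)[O-])noc2-c2ccc(Cl)cc2)cc1OC` has methoxy in place of hydrogen on an aromatic carbon, ortho to a methoxy group: methoxy in place of hydrogen on an aromatic carbon. Among the measured compounds shown here, the one measured step that bears on this is a 1.0-fold lower number from compound 2 to compound 3 (0.01 log units; within the scatter), which also brought in a methoxy on an aromatic carbon. No change beyond the scatter is therefore expected in this assay. The expected step is a 1.1-fold lower number from compound 3 to compound 4 (0.02 log units; within the scatter). Compound 4 is estimated at 85000 nM, within a range of 45000 nM to 160000 nM.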

Compound 4, half-maximal cytotoxic concentration: 106000 nM
Beside the measured number, compound 4's estimate is 1.2-fold (0.10 log units) below it; the measured number falls inside the stated range.
By their numbers in this assay, from the lowest: compounds 3, 2 and 4 (each within the scatter of the next).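

In this assay, a methoxy on an aromatic carbon, ortho to a methoxy group, gives a 1.2-fold higher number from compound 3 to compound 4 (0.07 log units; within the scatter). The earlier step exchanged one ring group for another, whereas this one fills a carbon that carried only hydrogen, and the number still stays within the scatter. Nothing measured here offers an explanation for this result. As far as these compounds go, whether this position would tolerate a different kind of group, such as an amine, a carboxylic acid or a longer chain, stays open. So does whether larger steps appear with those groups.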